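The compounds below may be only part of what the source reports. "The series", "measured", "known", "first", "only" and "open" are said of these compounds alone.

In an ADME assay on Vero cells (Chlorocebus sabaeus) for cytotoxicity (a higher number here means that more compound is tolerated, a lower number that less compound is tolerated), three compounds of one series have been tested. Compound 1 `O=C(O)c1cccc(-c2ccc(/C=C3\S/C(=N\c4ccccc4)N(c4ccc(Cl)cc4)C3=O)o2)c1` carries a 4-chlorophenyl group on the amide-type nitrogen of its five-membered ring; in this assay compound 1 gives > 200000 nM, which is a limit of the assay and not a number. Compound 2 `O=C(O)c1cccc(-c2ccc(/C=C3\S/C(=N\c4ccccc4)N(c4ccc(F)cc4)C3=O)o2)c1` differs by fluoro in place of chloro on an aromatic carbon; in this assay compound 2 gives > 200000 nM, again a limit. Compound 3 `O=C(O)c1cccc(-c2ccc(/C=C3\S/C(=N\c4ccccc4)N(c4ncccc4F)C3=O)o2)c1` carries a 3-fluoropyridin-2-yl group on that nitrogen; in this assay compound 3 gives > 200000 nM, also a limit. The step that the two limits leave unreadable from compound 1 to compound 2, the step that the two limits leave unreadable from compound 1 to compound 3 and the step that the two limits leave unreadable from compound 2 to compound 3 cannot be read, because of the limit of > 200000 nM in this assay, at which 3 of the 3 values shown sit. Compound 3 thus stands at the limit, with only a limit and no number known for it. All three values shown sit there.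

Compound 4 `O=C(O)c1cccc(-c2ccc(/C=C3\S/C(=N\c4ccccc4)N(c4ccc(F)cn4)C3=O)o2)c1` is the next compound to be tested. It differs from compound 3 as follows: 5-fluoropyridin-2-yl in place of 3-fluoropyridin-2-yl on an amide-type nitrogen in a ring. Every measured step in the series sits at the limit, so none of them bears on this change in a readable way, and no step beyond the scatter is expected in this assay. Compound 4 is expected to give 200000 nM in this assay, with a range from 100000 nM to 400000 nM. The step of a number no higher from compound 3 to compound 4 (the limit leaves the size open) that this estimate means is expected to lie within the scatter.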

Compound 4, half-maximal cytotoxic concentration: > 200000 nM
Compound 4 ended at the assay's limit; the forecaster's own chance of this, stated with the estimate: 85%; the middle value sits exactly at the limit.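

In this assay compound 4 gives > 200000 nM, which is a limit and not a number. Its steps from compound 1, compound 2 and compound 3 therefore cannot be read: the limit of > 200000 nM in this assay, at which 4 of the 4 values shown sit.

The compounds shown leave open whether the group on the amide-type nitrogen affects how much compound is tolerated in this assay at all.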